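This account rests on a few compounds, and the source may have more. Where it says the series, first, only, none or still open, it means among the compounds named here.

Three compounds share one core and differ only in the group on a single aromatic carbon. Compound 1 `CCCN(c1nccc(-c2c(OC)cc(OC)cc2OC)n1)C(C1CC1)C1CC1` carries a methoxy there and in an assay on CHO cells for displacement of a labelled ligand from corticotropin-releasing factor receptor 1 (Homo sapiens) (a higher number here means a weaker inhibitor, a lower number a stronger inhibitor), compound 1 gives 15 nM. Compound 2 `CCCN(c1nccc(-c2ccc(OC)cc2OC)n1)C(C1CC1)C1CC1` carries hydrogen at that carbon, and compound 2 gives 460 nM. Compound 3 `CCCN(c1nccc(-c2c(F)cc(OC)cc2OC)n1)C(C1CC1)C1CC1` carries fluoro, and compound 3 gives 63 nM, the second highest of the three numbers. The steps of a 4.2-fold higher number from compound 1 to compound 3 (0.62 log units; beyond the scatter) and a 7.3-fold lower number from compound 2 to compound 3 (0.86 log units; beyond the scatter) show how much this one carbon matters. Compound 4 `CCCN(c1nccc(-c2c(Cl)cc(OC)cc2OC)n1)C(C1CC1)C1CC1` differs from compound 3 in one place: chloro in place of fluoro on an aromatic carbon. Given the modest sizes of a 4.2-fold higher number from compound 1 to compound 3 (0.62 log units; beyond the scatter) and a 7.3-fold lower number from compound 2 to compound 3 (0.86 log units; beyond the scatter) for changes at this carbon, the expected step of a 1.8-fold lower number from compound 3 to compound 4 (0.26 log units; within the scatter) is a small lowering, within the scatter. Compound 4 is therefore estimated at 35 nM, with a range from 10 nM to 120 nM.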

Compound 4, inhibition constant: 11 nM
Compound 4: the middle estimate sits 3.2-fold (0.50 log units) above what was measured; the range from low to high includes it.
By their numbers in this assay, from the lowest: compounds 4 and 1 (each within the scatter of the next); then compound 3; then compound 2.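

Fluoro and chloro do not behave alike at this carbon, with a 5.7-fold lower number from compound 3 to compound 4 (0.76 log units; beyond the scatter) as the step between them. Chloro also stands far from hydrogen, with a 42-fold lower number from compound 2 to compound 4 (1.62 log units; beyond the scatter) showing that a single atom here can carry most of the difference. Methoxy and chloro cannot be told apart, with a 1.4-fold lower number from compound 1 to compound 4 (0.13 log units; within the scatter) between them, so two quite different groups give matching numbers.

Nothing available explains why chloro and fluoro differ. As far as these compounds go, whether bromo, methyl or an amine at this carbon would match chloro remains open.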